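Swapping Trifluoromethyl for a Nitrile: Expected Potency

The source may report more compounds than this note shows. Statements on the series, on what has been measured and on what is new or still open speak of the compounds shown alone.

Compound 1 `CC(=O)Nc1cccc(C2CCN(CCn3c(-c4ccccc4)nc4ccccc43)CC2)c1`: 10000 nM
Compound 2 `CC(=O)Nc1cccc(C2CCN(CCCn3c(-c4cccc(C(F)(F)F)c4)nc4ccccc43)CC2)c1`: 30 nM
Compound 3 `COc1ccc(-c2nc3ccccc3n2CCCN2CCC(c3cccc(NC(C)=O)c3)CC2)cc1`: 9 nM

These three compounds were tested in an assay for displacement of a labelled ligand from melanin-concentrating hormone receptor 1 (Homo sapiens), read by fluorescence; a higher number here means a weaker inhibitor, a lower number a stronger inhibitor. Compound 2 gives 30 nM, the second highest of the three numbers; compound 3 lies nearest with 9 nM, while compound 1 lies furthest with 10000 nM. Compound 4 `CC(=O)Nc1cccc(C2CCN(CCCn3c(-c4ccc(C#N)cc4)nc4ccccc43)CC2)c1` is not yet measured. It differs from compound 2 in one place: 4-cyanophenyl in place of 3-(trifluoromethyl)phenyl on an aromatic carbon. Within the data shown here, the only measured step that bears on this is the exchange of the same ring at the same place, a 3.3-fold lower number from compound 2 to compound 3 (0.52 log units; beyond the scatter), a modest improvement. Compound 4 carries yet another group. That step serves only as a rough guide. A modest step toward a lower number is therefore expected, a 2.0-fold lower number from compound 2 to compound 4 (0.30 log units; within the scatter). Compound 4 is estimated at 15 nM, within a range from 4 nM to 60 nM.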

Compound 4, half-maximal inhibitory concentration: 16 nM
The estimate for compound 4 lay 1.1-fold (0.03 log units) below the measured number; low and high end bracket the measured number.
By their numbers in this assay, from the lowest: compounds 3, 4 and 2 (each within the scatter of the next, the first and the last beyond it); then compound 1.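

On the aromatic carbon between two ring nitrogen atoms, 4-cyanophenyl in place of 3-(trifluoromethyl)phenyl gives a 1.9-fold lower number from compound 2 to compound 4 (0.27 log units; within the scatter) in this assay, so these two rings cannot be told apart here. Cyano in place of methoxy on the phenyl ring gives a 1.8-fold higher number from compound 3 to compound 4 (0.25 log units; within the scatter), so compound 4 cannot be separated from compound 3 either, even though compound 2 and compound 3 differ beyond the scatter. Nothing available explains these numbers. Still open, as far as these compounds go, is how an amine or a carboxylic acid in place of the nitrile would read in this assay.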